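Two Methoxy Groups in Place of One on the Aryl Hydrazone

A few compounds are considered here, and "the series" means these few. Any claim that something is new, unique, unknown or untested is made for them only; others in the source may bear on it.

The series shares a core in which an aryl hydrazone is joined through a carbonyl to a pyridine bearing a trifluoromethylphenyl amine; it was tested in a functional assay on the whole organism (strain Wistar) for inhibition, with Rattus norvegicus as the target, read by paw edema, with a stated time of 30 min, at a dose of 10 mg/kg by the intraperitoneal route; on this read-out higher numbers stand for more inhibition at the one dose given (going by the name of the read-out) and lower numbers for less inhibition. Compound 1, `O=C(N/N=C/c1ccc(F)cc1)c1cccnc1Nc1cccc(C(F)(F)F)c1`, gives 33.9%. Compound 2, `O=C(N/N=C/c1ccc(O)c(O)c1)c1cccnc1Nc1cccc(C(F)(F)F)c1`, gives 51.4%. Compound 3, `COc1cccc(/C=N/NC(=O)c2cccnc2Nc2cccc(C(F)(F)F)c2)c1`, gives 52.8%, the highest of the three numbers, although the gap to compound 2 is within the scatter and only the gap to compound 1 lies beyond it.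

Compound 4, `COc1ccc(/C=N/NC(=O)c2cccnc2Nc2cccc(C(F)(F)F)c2)c(OC)c1`, has not yet been measured in this assay. It differs from compound 3 as follows: 2,4-dimethoxyphenyl in place of 3-methoxyphenyl on a carbon with a double bond to nitrogen.

Going by the values given here, the steps that bear on this are those at the same aryl position. Replacing 4-fluorophenyl moved the read-out by a number 17.5 percentage points higher from compound 1 to compound 2 (beyond the scatter) and by a number 18.9 percentage points higher from compound 1 to compound 3 (beyond the scatter), both modest. Exchanging one oxygen-bearing aryl for another, however, gave a number 1.4 percentage points higher from compound 2 to compound 3 (within the scatter), which is within the scatter. Since compound 4 again carries an oxygen-bearing aryl, the expected step is small, a number 2.8 percentage points lower from compound 3 to compound 4 (within the scatter), with no clear direction beyond the scatter. Compound 4 is therefore estimated to give 50% in this assay, with a range from 38% to 62%.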

Compound 4, a percentage reported as inhibition, in the whole organism at one dose (the size of the read-out at that dose, not a potency): 37.8%
Compound 4: the middle estimate sits 12.2 percentage points above what was measured, and the stated range ends above it.
By their numbers in this assay, from the lowest: compounds 1 and 4 (each within the scatter of the next); then compounds 2 and 3 (each within the scatter of the next).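

In this assay the result separates two aryl groups that both carry oxygen on the carbon with a double bond to nitrogen: 2,4-dimethoxyphenyl gives a number 15 percentage points lower from compound 3 to compound 4 (beyond the scatter) and a number 13.6 percentage points lower from compound 2 to compound 4 (beyond the scatter), so oxygen on the aryl ring does not by itself place a compound with compound 2 and compound 3. The step from the fluorinated aryl is a number 3.9 percentage points higher from compound 1 to compound 4 (within the scatter), which shows that the rise seen with 3,4-dihydroxyphenyl and 3-methoxyphenyl does not extend to every oxygen-bearing aryl group among these compounds, and compound 4 is the one that goes against such a pattern. No measurement is available here that explains why this exchange lowers the read-out.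

On these data alone, whether the lower number goes with the added methoxy group or with where the methoxy groups stand remains open, as the change from 3-methoxyphenyl to 2,4-dimethoxyphenyl alters both at once. Also open, as far as these compounds go, is how an aryl group carrying an amine or a carboxylic acid would read at this position in this assay.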